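The source may report more compounds than this note shows. Statements on the series, on what has been measured and on what is new or still open speak of the compounds shown alone.

Compound 1 `COC(=O)C1=C(C)N(c2ccccc2)C=C(C)C1c1ccccc1` was tested in a functional assay, tested at 100 ug/mL (a higher number here means a weaker effect of the compound at the concentration tested, a lower number a stronger effect), and gave -14.1%. Compound 2 `COC(=O)C1=C(C)N(c2cccc(Cl)c2)C=C(C)C1c1ccccc1` carries one change, (chloro in place of hydrogen on an aromatic carbon), and in this assay compound 2 gave -12%. That change made a step of a number 2.1 percentage points higher from compound 1 to compound 2 (within the scatter). Compound 3 `CC1=C(C(=O)OC(C)(C)C)C(c2ccccc2)C=CN1c1ccccc1` has a different core; the difference between the two cores is not broken down here. In this assay compound 3 gave -23.1%.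

Compound 4 `CC1=C(C(=O)OC(C)(C)C)C(c2ccccc2)C=CN1c1ccc(Cl)cc1` is compound 3 with one change: chloro in place of hydrogen on an aromatic carbon. The chloro enters para to a large group in compound 4, whereas in compound 2 it entered meta to a large group, so this is the same kind of change, not the same one. Because the step of a number 2.1 percentage points higher from compound 1 to compound 2 (within the scatter) stayed within the scatter, a similarly small step is expected here, estimated as a number 3.1 percentage points higher from compound 3 to compound 4 (within the scatter). Compound 4 is therefore expected to give about -20% in this assay, estimated to fall between -33% and -7%.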

Compound 4, a percentage reported as activity, at one concentration (the size of the read-out at that concentration, not a potency): -19.2%
Compound 4: middle estimate off by 0.8 percentage points, on the low side; the range from low to high includes it.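

On the core of compound 3, chloro in place of hydrogen gave in this assay a step of a number 3.9 percentage points higher from compound 3 to compound 4 (within the scatter). Set beside the same change on the core of compound 1, the two steps agree: the same change on two cores in this assay, a number 2.1 percentage points higher (within the scatter) from compound 1 to compound 2 and a number 3.9 percentage points higher (within the scatter) from compound 3 to compound 4, 1.8 percentage points apart, within the scatter of two such steps So in this small set the change can be carried from one core to the other with a similarly small step expected, but that rests on only two pairs, and neither step on its own can be told apart from repeat-to-repeat noise, which means no real effect of chloro is shown and nothing is shown about any further core, nor does the agreement show that the place of the chloro is unimportant, since in compound 4 it stands para to a large group and in compound 2 elsewhere on that ring.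

The compounds shown leave open whether a different group on this ring, such as an amine or a carboxylic acid, would produce a step beyond the scatter. They also leave open what a longer chain at that place would do on either core.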